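Amide substituent change at the growth-inhibition limit

The source may hold more compounds than are shown below. What is called first, only, known or untested is meant among the compounds shown, and "the series" means these compounds.

In a functional assay on A549 cells (Homo sapiens) for inhibition, read by sulforhodamine B assay, with a stated time of 72 h (a lower number here means a stronger inhibitor of growth, a higher number a weaker inhibitor of growth), compound 1 (`CN1CCN(C(=O)/C=C/c2ccncc2-c2ccc3ccccc3c2)CC1`) gives > 10000 nM as a limit of the assay and not as a number. Compound 2 (`COC1CN(C(=O)/C=C/c2ccncc2-c2ccc3ccccc3c2)C1`) gives > 10000 nM in this assay as a limit too. Among the compounds with values here, compound 2 therefore has no numerical position, and the only other value beside it is also a limit.

Compound 3 (`NC(=O)/C=C/c1ccncc1-c1ccc2ccccc2c1`) differs from compound 2 by amino in place of 3-methoxyazetidin-1-yl on a carbonyl carbon with amino in place of 3-methoxyazetidin-1-yl on a carbonyl carbon. Within the data shown here, the same carbonyl carbon changed in the one measured step, which is a step that the two limits leave unreadable from compound 1 to compound 2 and so offers no size to carry forward. Among the measured compounds shown here, the series so far amounts to the limit of > 10000 nM in this assay, at which 2 of the 2 values shown sit, and sets no direction.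

No step beyond the scatter can be supported in this assay on this basis, so compound 3 is expected to stay near the same limit. The expected change is a step that the limit leaves unreadable from compound 2 to compound 3 and remains an estimate with no firm direction. For compound 3 the estimated value is 12000 nM with an expected range from 4000 nM to 30000 nM and a report of only a limit is the likelier outcome.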

Compound 3, concentration for 50% growth inhibition: > 10000 nM
Compound 3: a limit, no number (the forecaster's own chance of this, stated with the estimate: 70%); the middle value does not contradict the limit.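

Within the data shown here, compound 3 gives only a limit in this assay, so its steps to compound 1 and compound 2 cannot be read and no new step follows. The position of the series is: the limit of > 10000 nM in this assay, at which 3 of the 3 values shown sit.

The compounds shown leave open whether any substituent on this carbonyl carbon gives a numerical value in this assay, and in which direction such a change would run.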